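Amidine nitrogen substituent and HEK293 cytotoxicity

A few compounds are considered here, and "the series" means these few. Any claim that something is new, unique, unknown or untested is made for them only; others in the source may bear on it.

Measured so far:
compound 1, `Cc1ccc(S(=O)(=O)/N=C(/CCNC2=CC(=O)c3ccccc3C2=O)Nc2ccc(F)cc2)cc1`, gives 55100 nM in an ADME assay on HEK293 cells (Homo sapiens) for cytotoxicity, read by MTT assay, with a stated time of 48 h; a lower number here means a stronger inhibitor, a higher number a weaker inhibitor
compound 2, `Cc1ccc(S(=O)(=O)/N=C(/CCNC2=CC(=O)c3ccccc3C2=O)Nc2cc(F)c(F)c(F)c2)cc1`, gives 82600 nM
compound 3, `Cc1ccc(S(=O)(=O)/N=C(/CCNC2=CC(=O)c3ccccc3C2=O)NCc2ccccc2)cc1`, gives 80200 nM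

Compound 3 stands second highest of the three numbers; its nearest neighbour is compound 2 (a 1.0-fold lower number from compound 2 to compound 3 (0.01 log units; within the scatter)) and the furthest is compound 1 (a 1.5-fold higher number from compound 1 to compound 3 (0.16 log units; within the scatter)), both within the scatter, so no order can be read among them. Compound 4, `Cc1ccc(S(=O)(=O)/N=C(\N)CCNC2=CC(=O)c3ccccc3C2=O)cc1`, differs from compound 3 by hydrogen in place of benzyl on an amine nitrogen. Going by the values given here, no measured step removes the group on that nitrogen altogether; the steps that bear on it are exchanges of that group, a 1.5-fold higher number from compound 1 to compound 2 (0.18 log units; within the scatter) and a 1.0-fold lower number from compound 2 to compound 3 (0.01 log units; within the scatter), all within the scatter. The expectation in this assay is therefore no step beyond the scatter, a 1.1-fold lower number from compound 3 to compound 4 (0.03 log units; within the scatter). Compound 4 is estimated at 75000 nM, range 35000 nM to 160000 nM.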

Compound 4, half-maximal inhibitory concentration: 63100 nM
Estimate against measurement, compound 4: 1.2-fold (0.08 log units) above; the range from low to high includes it.
By their numbers in this assay, from the lowest: compounds 1, 4, 3 and 2 (each within the scatter of the next).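

Taking the substituent off the amine nitrogen altogether, rather than exchanging it, gives no step beyond the scatter in this assay (a 1.3-fold lower number from compound 3 to compound 4 (0.10 log units; within the scatter)), (a 1.3-fold lower number from compound 2 to compound 4 (0.12 log units; within the scatter)) and (a 1.1-fold higher number from compound 1 to compound 4 (0.06 log units; within the scatter)). Hydrogen, benzyl, 4-fluorophenyl and 3,4,5-trifluorophenyl at this nitrogen therefore cannot be ordered, so an aromatic ring on it is not required for these numbers. No measurement is at hand that explains this result.

Open, from the compounds shown here alone, is whether a longer chain ending in an amine or a carboxylic acid on this nitrogen would give a step beyond the scatter. Also open, going by these compounds, is whether changes elsewhere on the shared core would do so.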